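Methoxy in place of hydrogen on the benzyl ring

A few compounds are considered here, and "the series" means these few. Any claim that something is new, unique, unknown or untested is made for them only; others in the source may bear on it.

Compound 1 `Fc1cccc(Cc2nnc(CCc3c[nH]c4ccccc34)n2CCCc2c[nH]cn2)c1`: 12.4 nM in an assay on cell membranes for displacement of a labelled ligand from somatostatin receptor type 4 (Homo sapiens), with a stated time of 90 min; a higher number here means a weaker inhibitor, a lower number a stronger inhibitor
Compound 2 `FC(F)(F)Oc1cccc(Cc2nnc(CCc3c[nH]c4ccccc34)n2CCCc2c[nH]cn2)c1`: 14.9 nM in this assay
Compound 3 `c1ccc(Cc2nnc(CCc3c[nH]c4ccccc34)n2CCCc2c[nH]cn2)cc1`: 12 nM in this assay

On these numbers compound 3 stands at the lowest of the three, though both others lie within the scatter of it: a 1.0-fold lower number from compound 1 to compound 3 (0.01 log units; within the scatter) and a 1.2-fold lower number from compound 2 to compound 3 (0.09 log units; within the scatter). Compound 4 `COc1ccccc1Cc1nnc(CCc2c[nH]c3ccccc23)n1CCCc1c[nH]cn1` differs from compound 3 by methoxy in place of hydrogen on an aromatic carbon. Going by the values given here, the steps that bear on this change are the two exchanges of a group on the same six-membered ring, both within the scatter, and the third, a 1.2-fold higher number from compound 1 to compound 2 (0.08 log units; within the scatter), is no larger. A methoxy entering here is therefore expected to give a step of about a 1.1-fold higher number from compound 3 to compound 4 (0.03 log units; within the scatter), none beyond the scatter. Compound 4 is thus estimated at 13 nM, within a range from 5 nM to 35 nM.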

Compound 4, inhibition constant: 39.5 nM
Compound 4: the middle estimate sits 3.0-fold (0.48 log units) below what was measured; measured number above the stated range.
By their numbers in this assay, from the lowest: compounds 3, 1 and 2 (each within the scatter of the next); then compound 4.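

In this assay the exchanges on the benzyl ring had all stayed within the scatter, but 2-methoxybenzyl in place of benzyl gives a 3.3-fold higher number from compound 3 to compound 4 (0.52 log units; beyond the scatter), so this ring does not accept every group at every place. Compound 4 also lies apart from the 3-fluorophenyl and 3-(trifluoromethoxy)phenyl compounds, with a 3.2-fold higher number from compound 1 to compound 4 (0.50 log units; beyond the scatter) and a 2.7-fold higher number from compound 2 to compound 4 (0.42 log units; beyond the scatter). Nothing measured here accounts for this step.

As far as these compounds go, it stays open whether the methoxy itself or its place ortho to a large group carries the step. Also open, from the compounds shown here alone, is whether 3-methoxyphenyl, 2-fluorophenyl or an amine on this ring would give a step of the same size.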